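Removing the methoxy group: expected cytotoxicity of compound 3

This account rests on a few compounds, and the source may have more. Where it says the series, first, only, none or still open, it means among the compounds named here.

Two members of the series have been tested in an ADME assay on HEK293 cells (Homo sapiens) for cytotoxicity; a higher number here means that more compound is needed for the effect, a lower number that less compound is needed. Compound 1 `c1ccc2cc(C3CNCCNCCNCCN3)ccc2c1` reaches only the assay limit, giving > 200000 nM. Compound 2 `COc1ccc(C2CNCCNCCNCCN2)cc1` likewise returns a limit of > 200000 nM. For the measured compounds named here, compound 2 therefore stands at the ceiling of what this assay reports, and the only other value shown sits at the same ceiling, as the limit of > 200000 nM in this assay, at which 2 of the 2 values shown sit, records. Going by the values given here, no step between measured compounds is available, since no measured pair differs in a single place.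

Compound 3 `c1ccc(C2CNCCNCCNCCN2)cc1` differs from compound 2 by hydrogen in place of methoxy on an aromatic carbon. With both measured compounds at the limit, nothing in the numbers points toward a change beyond the scatter in this assay. Compound 3 is expected to sit at or near the same ceiling, the estimated step from compound 2 being a number no higher from compound 2 to compound 3 (the limit leaves the size open). The estimate for compound 3 in this assay is 200000 nM, with a range from 100000 nM to 400000 nM.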

Compound 3, half-maximal effective concentration: > 200000 nM
Compound 3 was reported as a limit (the forecaster's own chance of this, stated with the estimate: 80%); the middle value lies on the limit itself.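

Compound 2 and compound 3 both stand at a limit in this assay, so no step between them can be read: the limit of > 200000 nM in this assay, at which 3 of the 3 values shown sit.

The compounds shown leave open what concentration produces the effect for any of them, and whether hydrogen in place of methoxy on an aromatic carbon changes it at all.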